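Aminopyrimidine series: aryl amine replacing hydroxyethyl amine

This account rests on a few compounds, and the source may have more. Where it says the series, first, only, none or still open, it means among the compounds named here.

Compound 1 `Cc1[nH]c2ccccc2c1-c1ccnc(NCCO)n1` is measured in an assay on isolated protein for inhibition of interferon-induced, double-stranded RNA-activated protein kinase (Homo sapiens), read by luminescence, with a stated time of 10 min (on this read-out higher numbers stand for weaker inhibition and lower numbers for stronger inhibition), where compound 1 gives 11000 nM. Compound 2 `OCCNc1nccc(-c2c[nH]c3ccccc23)n1` gives 11000 nM in this assay, and compound 3 `CN1CCN(c2ccc(Nc3ncnc4ccc([N+](=O)[O-])cc34)cc2)CC1` gives 15000 nM. Compound 1 stands level with compound 2 at the digits shown, the two together the lowest of the three numbers, and the gap to compound 3 is within the scatter, so no ordering among the three is supported.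

Among the compounds with values here, the one step inside the set, no change at the digits printed from compound 1 to compound 2 (within the scatter), swaps hydrogen for methyl on an aromatic carbon and leaves the number where it was.

Compound 4 `Cc1[nH]c2ccccc2c1-c1ccnc(Nc2ccccc2Cl)n1` has not been measured. It differs from compound 1 by 2-chlorophenyl in place of 2-hydroxyethyl on a nitrogen on an aromatic ring. Within the data shown here, no measured step touches this position: the only step available concerns a different site and is flat, and compound 3 carries a different core. Among the measured compounds shown here, a step of any size from compound 1 to compound 4 in this assay therefore has no precedent here. The expectation is a number near that of compound 1, with wide uncertainty, and the expected step is a 1.4-fold lower number from compound 1 to compound 4 (0.14 log units; within the scatter). Compound 4 is estimated at 8000 nM, in the range 2000 nM to 30000 nM.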

Compound 4, half-maximal inhibitory concentration: 19000 nM
Compound 4: the middle estimate sits 2.4-fold (0.38 log units) below what was measured; low and high end bracket the measured number.
By their numbers in this assay, from the lowest: compounds 1, 2, 3 and 4 (each within the scatter of the next).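

Within the data shown here, this is the first reading at this position: in this assay, 2-chlorophenyl in place of 2-hydroxyethyl on a nitrogen on an aromatic ring gives a 1.7-fold higher number from compound 1 to compound 4 (0.24 log units; within the scatter). The change removes a chain with a hydrogen-bond donor and acceptor and brings in a larger aromatic ring with neither, yet the step does not separate the two groups on this read-out. No supporting measurement bears on this result.

Open, on these data alone, is whether any group on this nitrogen moves the number beyond the scatter, for example an unsubstituted phenyl, a longer chain ending in a carboxylic acid, or an ethyl chain carrying a dimethylamino group. Also open, as far as these compounds go, is whether hydrogen in place of methyl on the aromatic carbon stays flat when 2-chlorophenyl is present.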